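The source may hold more compounds than are shown below. What is called first, only, known or untested is meant among the compounds shown, and "the series" means these compounds.

Compound 1 `Cc1ccc(S(=O)(=O)Nc2ccc(-c3nc4ccccc4o3)cc2)cc1`: > 100000 nM
Compound 2 `O=S(=O)(Nc1ccc2oc(-c3ccccc3)nc2c1)c1ccc(C(F)(F)F)cc1`: > 100000 nM

Both readings come from an assay on cells for inhibition of HSP60/HSP10 (Homo sapiens), with a stated time of 60 min; a lower number here means a stronger inhibitor, a higher number a weaker inhibitor. For compound 1 the value > 100000 nM is a limit of the assay, not a number. For compound 2 the value > 100000 nM is likewise only a limit. Going by the values given here, compound 1 therefore stands at the edge of what this assay can report, a place it shares with the only other measured compound, as the limit of > 100000 nM in this assay, at which 2 of the 2 values shown sit, shows. Compound 3 `Cc1cccc(S(=O)(=O)Nc2ccc(-c3nc4ccccc4o3)cc2)c1` is not yet measured; it differs from compound 1 by 3-methylphenyl in place of 4-methylphenyl on a sulfonyl sulfur. Among the compounds with values here, no step between measured compounds exists to gauge a change of this kind. Since compound 1 sits at the limit > 100000 nM, the expected step that the limit leaves unreadable from compound 1 to compound 3 is none beyond the scatter, in either direction. Compound 3 is expected to give 150000 nM, within 50000 nM to 500000 nM, and most likely to be reported again only as a limit.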

Compound 3, half-maximal inhibitory concentration: > 100000 nM
Compound 3: a limit, no number; the forecaster's own chance of this, stated with the estimate: 85%; the middle value is on the limit's open side.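

No step can be read from compound 1 to compound 3, with 3-methylphenyl in place of 4-methylphenyl, as both give only a limit: the limit of > 100000 nM in this assay, at which 3 of the 3 values shown sit.

The compounds shown leave open which change, if any, would give an actual number in this assay.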